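The source may hold more compounds than are shown below. What is called first, only, known or untested is meant among the compounds shown, and "the series" means these compounds.

Measured compounds:
Compound 1, `Nc1sc(-c2ccc(Cl)cc2)c(-c2ccc(Cl)cc2)c1C(=O)NC1CC1`: 3680 nM
Compound 2, `Nc1sc(-c2ccc(Cl)cc2)c(-c2ccc(Cl)cc2)c1C(=S)NC1CC1`: 22100 nM

In a functional assay on PC-3 cells (Homo sapiens) for cytotoxicity, read by sulforhodamine B assay, with a stated time of 72 h (on this read-out higher numbers stand for weaker inhibition and lower numbers for stronger inhibition), compound 2 gives 22100 nM, the highest of the two numbers measured, meaning the weaker inhibitor of the pair. Its nearest neighbour is compound 1, which in this assay gives 3680 nM. Among the measured compounds shown here, the single measured step, a 6.0-fold higher number from compound 1 to compound 2 (0.78 log units; beyond the scatter), swaps the carbonyl of the amide for a thiocarbonyl and leaves the ring on the amide-type nitrogen untouched.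

Compound 3, `Nc1sc(-c2ccc(Cl)cc2)c(-c2ccc(Cl)cc2)c1C(=S)NC1CCCC1`, differs from compound 2 by cyclopentyl in place of cyclopropyl on an amide-type nitrogen. For the measured compounds named here, no measured step touches this ring, so the data give no direct guide to the size or direction of the change. The expectation is therefore a step of a 1.1-fold lower number from compound 2 to compound 3 (0.04 log units; within the scatter), with no clear movement beyond the scatter. Compound 3 is estimated at 20000 nM, with a plausible range from 6000 nM to 60000 nM.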

Compound 3, half-maximal inhibitory concentration: 29000 nM
Compound 3: middle estimate off by 1.5-fold (0.16 log units), on the low side; low and high end bracket the measured number.
By their numbers in this assay, from the lowest: compound 1; then compounds 2 and 3 (each within the scatter of the next).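

In this assay, among the compounds shown here, the first change at this position, cyclopentyl in place of cyclopropyl on an amide-type nitrogen, gives a 1.3-fold higher number from compound 2 to compound 3 (0.12 log units; within the scatter), so on the thiocarbonyl compounds these two rings cannot be told apart. The other new step, a 7.9-fold higher number from compound 1 to compound 3 (0.90 log units; beyond the scatter), changes the carbonyl to a thiocarbonyl and the ring together, so it cannot separate their contributions, but it does leave both thiocarbonyl compounds printed as weaker than the carbonyl compound 1. Nothing available offers an explanation for these results.

The compounds shown leave open whether cyclopentyl would also make no clear difference alongside a carbonyl rather than a thiocarbonyl. They also leave open what would happen on this nitrogen with something other than a small carbon ring, such as a longer chain, an amine or a carboxylic acid.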